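Demethylation on a benzofuran ketone and its effect on transporter inhibition

This account rests on a few compounds, and the source may have more. Where it says the series, first, only, none or still open, it means among the compounds named here.

Three compounds sharing a ketone-linked benzofuran scaffold have been examined in an assay for inhibition of solute carrier family 22 member 12 (Homo sapiens), read by scintillation counting, with a stated time of 60 min, tested at 50 uM; a higher number here means more inhibition at the concentration tested (going by the name of the read-out), a lower number less inhibition. Compound 1 `CCc1cc2cc(OC)cc(C(=O)c3ccc(OC)cc3)c2o1` gives 5.2% in this assay, the lowest of the three numbers. Compound 2 `CCc1cc2c(C(=O)c3ccc(O)cc3)c(OC)ccc2o1` gives 88.2% in this assay, and compound 3 `CCc1cc2c(C(=O)c3ccc(O)cc3)c(O)ccc2o1` gives 51.5% in this assay. The difference between the core of compound 1 and the core of compound 2 is not broken down here.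

Compound 3 arises from compound 2 by the change (hydrogen in place of methyl on an oxygen on an aromatic ring), and the step of a number 36.7 percentage points lower from compound 2 to compound 3 (beyond the scatter) is large. Compound 4 `CCc1cc2cc(OC)cc(C(=O)c3ccc(O)cc3)c2o1` arises from compound 1 by the change (hydrogen in place of methyl on an oxygen on an aromatic ring), which is the same change made at a place described in the same words.

For compound 4 the expected step in this assay is a number 0.2 percentage points lower from compound 1 to compound 4 (within the scatter); this expectation rests on compound 1 standing at 5.2%, leaving little room to fall, and on the same change having lowered the number in the step of a number 36.7 percentage points lower from compound 2 to compound 3 (beyond the scatter). Compound 4 is therefore estimated at 5%, with a range from 0% to 25%.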

Compound 4, a percentage reported as inhibition, at one concentration (the size of the read-out at that concentration, not a potency): 60%
For compound 4 the middle estimate is 55 percentage points below the measured one, and the stated range ends below it.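

On the core of compound 1, exchanging methoxy for hydroxy in this assay gives a number 54.8 percentage points higher from compound 1 to compound 4 (beyond the scatter), so the exchange keeps neither its direction nor its size when moved from one core to the other: the same change on two cores in this assay, a number 36.7 percentage points lower (beyond the scatter) from compound 2 to compound 3 and a number 54.8 percentage points higher (beyond the scatter) from compound 1 to compound 4, 91.5 percentage points apart, beyond the scatter of two such steps. This shows that, in this series, the outcome of the exchange on one core cannot be taken as a guide to its outcome on the other, at least for these two pairs. It does not show why the steps differ, and core and site cannot be separated here, since the structures show that the oxygen losing its methyl sits on a different ring in each pair, although both places read as an oxygen on an aromatic ring.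

Going by these compounds alone, with only two pairs, no general rule for the exchange can be drawn. Still open, from the compounds shown here alone, is what a carboxylic acid or an amine would do in place of the hydroxy of compound 4, and what a longer chain would do in place of its ethyl group.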